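Swapping Chloro for Methoxycarbonyl: Expected Lipophilicity of Compound 4

This account rests on a few compounds, and the source may have more. Where it says the series, first, only, none or still open, it means among the compounds named here.

Compound 1 `CCCCCCCCc1ccc(OCC(=O)Cn2nnc(-c3ccc(Cl)cc3)n2)cc1`: > 8
Compound 2 `CCCCCCCCc1ccc(OCC(=O)Cn2nnc(-c3ccc(C(=O)OC)cc3)n2)cc1`: 8
Compound 3 `CCCCCCCCc1ccc(OC(C)C(=O)Cn2nnc(-c3ccc(Cl)cc3)n2)cc1`: > 8

In a physicochemical assay for lipophilicity, read by HPLC, tested at 5 mM (on this read-out lower numbers stand for lower lipophilicity and higher numbers for higher lipophilicity), compound 2 gives 8. The value of compound 1 is a limit of this assay, not a number. The value of compound 3 is likewise a limit of this assay. The change methoxycarbonyl in place of chloro on an aromatic carbon gave a number no higher from compound 1 to compound 2 (the limit leaves the size open). The cores of compound 1 and compound 3 differ by methyl in place of hydrogen on a saturated chain carbon bound to a carbonyl carbon and an oxygen on an aromatic ring, and this gave a step that the two limits leave unreadable from compound 1 to compound 3. Compound 4 `CCCCCCCCc1ccc(OC(C)C(=O)Cn2nnc(-c3ccc(C(=O)OC)cc3)n2)cc1` has not yet been measured; it differs from compound 3 by methoxycarbonyl in place of chloro on an aromatic carbon, the same change as between compound 1 and compound 2, at a place described in the same words. Going by the values given here, because of the limit of > 8 in this assay, at which 2 of the 3 values shown sit, only the step from compound 1 to compound 2 gives a readable direction. From compound 3 to compound 4 a step that the limit leaves unreadable from compound 3 to compound 4 is expected, resting on a number no higher from compound 1 to compound 2 (the limit leaves the size open). Compound 4 is expected to give 8.2 in this assay, between 7.7 and 8.7.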

Compound 4, partition coefficient: > 8
Compound 4: only a limit was reported; the forecaster's own chance of this, stated with the estimate: 50%; the middle value is on the limit's open side.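

In this assay compound 4 gives > 8, which is a limit of the assay and not a number. Placing methyl in place of hydrogen on the saturated chain carbon gave a number no lower from compound 2 to compound 4 (the limit leaves the size open). Whether swapping chloro for methoxycarbonyl does the same on the core of compound 3 as on the core of compound 1 remains unshown, and the steps between two limits cannot be read, because so many values rest on one limit: the limit of > 8 in this assay, at which 3 of the 4 values shown sit.

The compounds shown leave open what a carboxylic acid or an amine in place of chloro would give in this assay. They also leave open whether a shorter chain in place of the octyl chain would yield readable numbers.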